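The compounds below may be only part of what the source reports. "The series", "measured", "known", "first", "only" and "open" are said of these compounds alone.

Values in a functional assay on A549 cells (Homo sapiens) for antiproliferative activity, read by MTT assay, with a stated time of 72 h; on this read-out lower numbers stand for stronger inhibition and higher numbers for weaker inhibition:
compound 1, `CCOC1=C(C(=O)c2ccccc2)C(c2ccc(Br)cc2)N(CCCn2ccnc2)C1=O`: 35300 nM
compound 2, `CCCCOC1=C(C(=O)c2ccccc2)C(c2ccc(Br)cc2)N(CCCn2ccnc2)C1=O`: 18500 nM
compound 3, `Cc1ccc(NC2=C(C(=O)c3ccccc3)C(c3ccc(Br)cc3)N(CCCn3ccnc3)C2=O)cc1`: 29400 nM

Compound 3 holds the second highest of the three numbers in this assay; its nearest neighbour is compound 1, and its gap to compound 2 is also within the scatter, so no order among the three can be read from these values. The measured steps are all small: a 1.9-fold lower number from compound 1 to compound 2 (0.28 log units; within the scatter), a 1.2-fold lower number from compound 1 to compound 3 (0.08 log units; within the scatter), and a 1.6-fold higher number from compound 2 to compound 3 (0.20 log units; within the scatter).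

Compound 4, `O=C(C1=C(Nc2ccc(Br)cc2)C(=O)N(CCCn2ccnc2)C1c1ccc(Br)cc1)c1ccccc1`, differs from compound 3 in one place: bromo in place of methyl on an aromatic carbon. Among the measured compounds shown here, none of the measured steps touches the (4-methylphenyl)amino group itself; the two steps involving compound 3 exchange the whole group for an alkoxy, and the step from compound 1 to compound 2 lengthens an alkoxy chain. For the measured compounds named here, all three lie within the scatter, and the series so far gives no example of a substituent swap on that aromatic ring. On this basis the expected step in this assay from compound 3 to compound 4 is none beyond the scatter, in either direction, a 1.0-fold higher number from compound 3 to compound 4 (0.01 log units; within the scatter). Compound 4 is therefore estimated at 30000 nM in this assay, with a range from 12000 nM to 75000 nM.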

Compound 4, half-maximal inhibitory concentration: 22200 nM
For compound 4 the middle estimate is 1.4-fold (0.13 log units) above the measured one; the measured number falls inside the stated range.
By their numbers in this assay, from the lowest: compounds 2, 4, 3 and 1 (each within the scatter of the next).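

In this assay, among the compounds shown here, the exchange of bromo for methyl, para to a large group on the aromatic ring, is the first direct substituent swap on that ring, and it stays within the scatter (a 1.3-fold lower number from compound 3 to compound 4 (0.12 log units; within the scatter)). The (4-bromophenyl)amino group also stays within the scatter when compared with either alkoxy group (a 1.2-fold higher number from compound 2 to compound 4 (0.08 log units; within the scatter) and a 1.6-fold lower number from compound 1 to compound 4 (0.20 log units; within the scatter)), so the two arylamino compounds and the two alkoxy compounds show no separation from one another at this ring carbon, and no order can be read among compounds 1 to 4. No supporting data bear on the reason for this flat result.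

With only methyl and bromo compared at this place on the aromatic ring, the series leaves open how a carboxylic acid, an amine or a nitrile there would read in this assay. Going by these compounds, it is also open whether any group on the double-bonded ring carbon, such as a longer alkoxy chain or a benzylamino group, would give a step beyond the scatter from the shared core.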